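The source may hold more compounds than are shown below. What is called first, only, known or untested is meant among the compounds shown, and "the series" means these compounds.

- compound 1 `CN1C[C@@H]2C[C@H]1CN2c1cc(F)c(-c2ccnc3c(-c4cccc5[nH]ncc45)c(-c4ccncc4)nn23)cc1F`: 87 nM
- compound 2 `CN1C[C@@H]2C[C@H]1CN2c1cc(F)c(-c2ccnc3c(-c4ccc(F)c5[nH]ncc45)c(-c4ccncc4)nn23)c(F)c1`: 17 nM
- compound 3 `CCN1C[C@@H]2C[C@H]1CN2c1cc(F)c(-c2ccnc3c(-c4cccc5[nH]ncc45)c(-c4ccncc4)nn23)c(F)c1`: 56 nM
- compound 4 `CC(C)N1C[C@@H]2C[C@H]1CN2c1cc(F)c(-c2ccnc3c(-c4cccc5[nH]ncc45)c(-c4ccncc4)nn23)c(F)c1`: not yet measured

These three values come from a functional assay on A-375 cells (Homo sapiens) for inhibition, read by MTT assay, with a stated time of 4 days; a lower number here means a stronger inhibitor, a higher number a weaker inhibitor. There, compound 3 at 56 nM cannot be told apart from compound 1 at 87 nM, since the two lie within the usual scatter. Compound 2 at 17 nM gives a lower number than compound 3, and that gap lies beyond the scatter.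

Compound 4 differs from compound 3 by methyl in place of hydrogen on a saturated chain carbon bound to an amine nitrogen in a ring and a saturated chain carbon. In words, this is methyl in place of hydrogen on a saturated chain carbon bound to an amine nitrogen in a ring and a saturated chain carbon, so ethyl becomes isopropyl.

Among the compounds with values here, no measured pair shows this change, so the data offer no direct guide to its effect. The best anchor is compound 3 at 56 nM, and no step beyond the scatter is expected in this assay. The estimated change is a 1.2-fold higher number from compound 3 to compound 4 (0.06 log units; within the scatter), with no firm direction. For compound 4 the expected value is 65 nM, with an estimated range of 28 nM to 150 nM.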

Compound 4, half-maximal inhibitory concentration: 55 nM
For compound 4 the middle estimate is 1.2-fold (0.07 log units) above the measured one; the range from low to high includes it.
By their numbers in this assay, from the lowest: compound 2; then compounds 4, 3 and 1 (each within the scatter of the next).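

In this assay, putting methyl in place of hydrogen on a saturated chain carbon bound to an amine nitrogen in a ring and a saturated chain carbon turns ethyl into isopropyl and gives a 1.0-fold lower number from compound 3 to compound 4 (0.01 log units; within the scatter) so the two compounds cannot be told apart. Within the data shown here, this is the first direct reading of this change at this position, and it shows that the ethyl group can carry this added methyl with no difference that this assay can resolve. No measurement shown here explains why the step is so small.

Going by these compounds, it remains open whether a larger group in the same place, such as tert-butyl or a longer chain ending in a carboxylic acid, would also leave the number unmoved. On these data alone, it is equally open whether isopropyl would behave the same way on a core carrying the extra fluorine seen in compound 2.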